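Adding a propyl group to compound 2

The source may report more compounds than this note shows. Statements on the series, on what has been measured and on what is new or still open speak of the compounds shown alone.

Compound 1 (`COc1cccc(/C=C/C(=O)c2c(OC)cc(OC)c(CC=C(C)C)c2O)c1`) gives 49200 nM in an ADME assay on MCF7-DOX cells (Homo sapiens) for cytotoxicity, read by MTT assay, with a stated time of 48 h; a higher number here means a weaker inhibitor, a lower number a stronger inhibitor
Compound 2 (`COc1cc(O)c(C(=O)/C=C/c2cccc(N3CCNCC3)c2)c(OC)c1`) gives 99200 nM in this assay

Compound 2 (99200 nM) sits within the usual scatter of compound 1, so these two cannot be ranked. Compound 3 (`CCCc1c(OC)cc(OC)c(C(=O)/C=C/c2cccc(N3CCNCC3)c2)c1O`) is compound 2 with one change on the shared core: propyl in place of hydrogen on an aromatic carbon. Within the data shown here, no measured pair shows this change alone, so the data fix no size for it. Among the measured compounds shown here, the only hint comes from compound 1, which also carries a carbon chain on the core and gives 49200 nM in this assay while differing from compound 2 elsewhere too. Since its value stays within the scatter of that of compound 2, only a small move toward a lower number, meaning a slightly stronger inhibitor, is expected, and it may not clear the scatter. The estimated 1.4-fold lower number from compound 2 to compound 3 (0.15 log units; within the scatter) is correspondingly modest. In this assay compound 3 is estimated at 70000 nM (range 30000 nM to 150000 nM).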

Compound 3, half-maximal inhibitory concentration: > 100000 nM
Compound 3: a limit, no number (the forecaster's own chance of this, stated with the estimate: 10%); middle value at least 1.4-fold (0.15 log units) from the limit.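

Among these compounds, for the first time, this pair isolates one change: propyl in place of hydrogen on an aromatic carbon of the shared core, at the position ortho to a hydroxy group and ortho to a methoxy group. In this assay this gives a number no lower from compound 2 to compound 3 (the limit leaves the size open), so the change brings no gain in strength at this position, and the step has a direction but no measurable size, because the reading of compound 3 stops at the edge of what the assay reports: the limit of > 100000 nM in this assay, at which 1 of the 3 values shown sits. Compound 1 also carries a carbon chain on its core but differs from compound 2 elsewhere too. Among the compounds shown here, only this pair can show what a propyl group at this position does on its own, without those other differences.

As far as these compounds go, it remains open how far past the limit compound 3 truly lies, and so whether the propyl group costs a little strength or a great deal. Also open, from the compounds shown here alone, is how a methyl group, a longer chain such as hexyl, or an amine on this same aromatic carbon would read in this assay.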